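The source may report more compounds than this note shows. Statements on the series, on what has been measured and on what is new or still open speak of the compounds shown alone.

Values in an ADME assay on Vero 76 cells (Chlorocebus sabaeus) for cytotoxicity, read by crystal violet staining, with a stated time of 96 h; on this read-out higher numbers stand for lower toxicity in this test and lower numbers for higher toxicity in this test:
Compound 1 `CSCCCNC(=S)Nc1cccc(C(F)(F)F)c1`: > 100000 nM
Compound 2 `Fc1cccc(NC(=S)Nc2cccc(C(F)(F)F)c2)c1`: 20000 nM

Compound 1 stands at the limit of > 100000 nM in this assay, at which 1 of the 2 values shown sits, so its entry is a limit and not a number. Going by the values given here, compound 2, at 20000 nM, therefore holds the only actual number so far.

The next compound is compound 3 `FC(F)(F)c1cccc(NC(=S)Nc2ccccc2Br)c1`, which has 2-bromophenyl in place of 3-fluorophenyl on an amide-type nitrogen. Among the compounds with values here, the one measured step is an at least 5.0-fold lower number from compound 1 to compound 2 (0.69 log units; beyond the scatter). It bears on this change only loosely, since it put 3-fluorophenyl in place of 3-(methylsulfanyl)propyl, whereas here one six-membered aromatic ring of carbon only replaces another. Within the data shown here, no measured step shows such a swap between two rings. With compound 2 at 20000 nM as the closest reference, no step beyond the scatter is expected in this assay. The estimated change is a 1.3-fold lower number from compound 2 to compound 3 (0.12 log units; within the scatter). For compound 3 the expected value is 15000 nM, with an estimated range of 5000 nM to 50000 nM.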

Compound 3, half-maximal cytotoxic concentration: 50000 nM
Compound 3: the middle estimate sits 3.3-fold (0.52 log units) below what was measured; measured number inside the range.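

In this assay, exchanging one halogen-bearing aromatic ring for another on the amide-type nitrogen is not a neutral swap: 2-bromophenyl in place of 3-fluorophenyl gives a 2.5-fold higher number from compound 2 to compound 3 (0.40 log units; beyond the scatter). Going by these compounds alone, this modest step is the first between two actual numbers, and it shows that the details of the ring at this place can shift the read-out, with compound 3 the less toxic of this pair in this test. Compared with the 3-(methylsulfanyl)propyl chain, the same ring gives an at least 2.0-fold lower number from compound 1 to compound 3 (0.30 log units; that floor lies within the scatter), and compound 1 is entered only as a limit, so this comparison cannot firmly separate the two, because that entry gives no actual number: the limit of > 100000 nM in this assay, at which 1 of the 3 values shown sits.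

The two rings differ both in their halogen and in where it sits, so the compounds shown leave open which of these goes with the step; 2-fluorophenyl or 3-bromophenyl on the same nitrogen would separate the two. Also open, as far as these compounds go, is how a ring containing nitrogen, such as pyridyl, or a plain longer carbon chain would read at this place.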